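A few compounds are considered here, and "the series" means these few. Any claim that something is new, unique, unknown or untested is made for them only; others in the source may bear on it.

Measured so far:
compound 1 `C#CCN(C)Cc1cccc(NC(=O)CCC(=O)NO)c1`, > 10000 nM; compound 2 `C#CCN(C)Cc1cccc(NC(=O)CCCC(=O)NO)c1`, > 10000 nM; compound 3 `C#CCN(C)Cc1cccc(NC(=O)CCCCCCC(=O)NO)c1`, 420 nM.

In a functional assay on DU-145 cells (Homo sapiens) for inhibition, read by MTT assay, with a stated time of 48 h (on this read-out higher numbers stand for weaker inhibition of growth and lower numbers for stronger inhibition of growth), compound 1 gives only a limit, > 10000 nM. Compound 2 likewise gives only a limit, > 10000 nM. For the measured compounds named here, compound 3 gives 420 nM, the one number among the three. The other two sit at the limit of > 10000 nM in this assay, at which 2 of the 3 values shown sit. The change (hydroxycarbamoyl)methyl in place of hydroxycarbamoyl on a saturated chain carbon, two bonds along the chain from a carbonyl carbon gave a step that the two limits leave unreadable from compound 1 to compound 2. The cores of compound 1 and compound 3 differ by 4-(hydroxycarbamoyl)butyl in place of hydroxycarbamoyl on a saturated chain carbon, two bonds along the chain from a carbonyl carbon, a step of an at least 23-fold lower number from compound 1 to compound 3 (1.37 log units; beyond the scatter) in this assay; compound 2 to compound 3 is an at least 23-fold lower number from compound 2 to compound 3 (1.37 log units; beyond the scatter).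

Compound 4 `C#CCN(C)Cc1cccc(NC(=O)CCCCCCCC(=O)NO)c1` carries the same kind of change, ((hydroxycarbamoyl)methyl in place of hydroxycarbamoyl on a saturated chain carbon, six bonds along the chain from a carbonyl carbon), but six bonds along the chain from a carbonyl carbon rather than two. The earlier step being unreadable, the expected step of a 1.4-fold higher number from compound 3 to compound 4 (0.15 log units; within the scatter) rests only on the numbered value of compound 3, 420 nM, and is expected to stay within the scatter. For compound 4 the estimate is 600 nM, between 200 nM and 2000 nM.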

Compound 4, concentration for 50% growth inhibition: 3780 nM
Compound 4: the middle estimate sits 6.3-fold (0.80 log units) below what was measured; measured number above the stated range.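

In this assay, (hydroxycarbamoyl)methyl in place of hydroxycarbamoyl, six bonds along the chain from a carbonyl carbon, gives a 9.0-fold higher number from compound 3 to compound 4 (0.95 log units; beyond the scatter), so this extension does not lower the number here. Compared with compound 2, whose value is only a limit, 4-(hydroxycarbamoyl)butyl in place of hydroxycarbamoyl, three bonds along the chain from a carbonyl carbon, gives an at least 2.6-fold lower number from compound 2 to compound 4 (0.42 log units; beyond the scatter). The same change lowers the number on both cores, which shows a shared direction but gives no size that can be carried from one core to the other: the same change on two cores in this assay, an at least 23-fold lower number (1.37 log units; beyond the scatter) from compound 1 to compound 3 and an at least 2.6-fold lower number (0.42 log units; beyond the scatter) from compound 2 to compound 4; the limit leaves it open whether they differ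

The compounds shown leave open how chains of intermediate length between those of compound 2 and compound 3 behave, and how a longer chain than that of compound 4 behaves. They also leave open whether a carboxylic acid in place of hydroxycarbamoyl follows the same trend.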